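Chloro to Fluoro on a Core Without Measurable Cytotoxicity

The source may hold more compounds than are shown below. What is called first, only, known or untested is meant among the compounds shown, and "the series" means these compounds.

Measured compounds:
compound 1 `Cc1ccc2[nH]c(=O)c(-c3nc4cc(Cl)ccc4[nH]3)cc2c1` — in an ADME assay on L02 cells (Homo sapiens) for cytotoxicity, read by MTT assay, with a stated time of 48 h (on this read-out higher numbers stand for weaker inhibition and lower numbers for stronger inhibition), compound 1 gives > 100000 nM, a limit of the assay rather than a number.
compound 2 `O=c1[nH]c2ccccc2cc1-c1nc2cc(Cl)ccc2[nH]1` — in this assay compound 2 gives > 100000 nM, likewise a limit.

Among the compounds with values here, compound 1 therefore stands at the limit, not at a measured value, and the only other value shown is also a limit. Within the data shown here, the one step between measured compounds, a step that the two limits leave unreadable from compound 1 to compound 2, is hydrogen in place of methyl on an aromatic carbon, and its size cannot be read because of the limit of > 100000 nM in this assay, at which 2 of the 2 values shown sit.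

Compound 3 `Cc1ccc2[nH]c(=O)c(-c3nc4cc(F)ccc4[nH]3)cc2c1` differs from compound 1 by fluoro in place of chloro on an aromatic carbon. No measured step concerns a change at this place, so nothing shown speaks for or against movement here; the only step available is unreadable. The account expects compound 3 to remain at the limit as well, that is 100000 nM within 40000 nM to 250000 nM, a step of a number no higher from compound 1 to compound 3 (the limit leaves the size open) that is expected to lie within the scatter.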

Compound 3, half-maximal inhibitory concentration: > 100000 nM
Compound 3 gave a limit, no number (the forecaster's own chance of this, stated with the estimate: 85%); the middle value lies on the limit itself.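

In this assay compound 3 gives > 100000 nM, a limit of the assay, so no new step can be read between compound 1 and compound 3: the limit of > 100000 nM in this assay, at which 3 of the 3 values shown sit. The compounds shown leave open whether either change shifts cytotoxicity at all, and how far apart compound 1, compound 2 and compound 3 truly lie.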